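Inverting Both Ring Stereocentres of the Fluorocyclopropyl Amide

This account rests on a few compounds, and the source may have more. Where it says the series, first, only, none or still open, it means among the compounds named here.

Three amides built on a shared bicyclic diamine core have been measured. In an assay on SH-EP1 cells for agonist activity at Neuronal acetylcholine receptor; alpha4/beta2 (Homo sapiens), read by FLIPR and calcium flux (on this read-out lower numbers stand for smaller maximal responses and higher numbers for larger maximal responses), compound 1 `CC(=O)N1CC2CC(C1)N2` gives 95%, compound 2 `O=C(C1CCC1)N1CC2CC(C1)N2` gives 99%, and compound 3 `O=C([C@H]1C[C@H]1F)N1CC2CC(C1)N2` gives 110%. Compound 3 stands highest of the three: the steps of a number 15 percentage points higher from compound 1 to compound 3 (beyond the scatter) and a number 11 percentage points higher from compound 2 to compound 3 (beyond the scatter) are both beyond the scatter, whereas a number 4 percentage points higher from compound 1 to compound 2 (within the scatter) lies within it. Compound 4 `O=C([C@@H]1C[C@@H]1F)N1CC2CC(C1)N2` is the next candidate. Its relation to compound 3 is the two compounds have the same atoms and bonds; at least one stereo element is drawn with a configuration in one of them and without one in the other: 2 of 4 stereo elements differ; a stereocentre at a saturated ring carbon is drawn R in compound 3 and S in compound 4; a stereocentre at a saturated ring carbon is drawn R in compound 3 and S in compound 4. Within the data shown here, none of the measured steps concerns a stereochemical change; each replaces one group on the carbonyl carbon, so they show only that the 2-fluorocyclopropyl amide sits at the top of this small set, and give no direct guide to how its mirror-image arrangement will behave. The opposite enantiomer of an amide side chain may well read differently, so a modest drop is the most plausible expectation, with the step of a number 15 percentage points lower from compound 3 to compound 4 (beyond the scatter) expected to be small relative to the shown steps. Compound 4 is accordingly estimated at 95%, within a range of 70% to 115%.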

Compound 4, largest response reached (Emax), in percent of the reference or control that the assay uses: 110%
For compound 4 the middle estimate is 15 percentage points below the measured one, and the stated range covers the measured number.
By their numbers in this assay, from the lowest: compounds 1 and 2 (each within the scatter of the next); then compounds 3 and 4 (each within the scatter of the next).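

In this assay, among these compounds, inverting both ring stereocentres of the 2-fluorocyclopropyl group leaves the maximal response in place, with no change at the digits printed from compound 3 to compound 4 (within the scatter), so this amide position shows a tolerance to the drawn configuration that the earlier compounds, which differ only in the group on the carbonyl carbon, could not reveal. The advantage of this side chain also holds for the inverted form, with a number 11 percentage points higher from compound 2 to compound 4 (beyond the scatter) and a number 15 percentage points higher from compound 1 to compound 4 (beyond the scatter), so it is not confined to the arrangement drawn in compound 3. The stereochemical reading carries one qualification: the fact that one of compounds 3 and 4 is drawn with a defined configuration and the other without, at the place where they differ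

On these data alone, it remains open whether the fluorine itself is needed, since an unsubstituted cyclopropyl amide does not appear here. A 2-chlorocyclopropyl or 2,2-difluorocyclopropyl amide could show whether the response rises further or stays level.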